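Lengthening the linker chain between the two aryl ethers

A few compounds are considered here, and "the series" means these few. Any claim that something is new, unique, unknown or untested is made for them only; others in the source may bear on it.

Compound 1 `N=C(N)c1ccc2cc(-c3cccc(OCCCCOc4ccccc4)c3)oc2c1` is the shared starting point. Within the data shown here, in an ADME assay on L6 cells (Rattus norvegicus) for cytotoxicity, read by resazurin assay, with a stated time of 70 h (a higher number here means a weaker inhibitor, a lower number a stronger inhibitor), compound 1 gives 7600 nM, the highest of the two numbers so far. Compound 2 `c1ccc(OCCCCOc2cccc(-c3cc4ccc(C5=NCCN5)cc4o3)c2)cc1` gives 5800 nM in this assay; that change runs from one end group to another, a 1.3-fold lower number from compound 1 to compound 2 (0.12 log units; within the scatter), and tells nothing about the linker. Compound 3 `N=C(N)c1ccc2cc(-c3cccc(OCCCCCCOc4ccccc4)c3)oc2c1` differs from compound 1 only in the chain: 2-phenoxyethyl in place of phenoxy on a saturated chain carbon, four bonds along the chain from an oxygen on an aromatic ring. Among the measured compounds shown here, no measured step bears on such a change, so only a small step, if any, is expected, a 1.1-fold lower number from compound 1 to compound 3 (0.04 log units; within the scatter). Compound 3 is therefore estimated at 7000 nM, with a range from 3000 nM to 18000 nM.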

Compound 3, half-maximal inhibitory concentration: 4300 nM
For compound 3 the middle estimate is 1.6-fold (0.21 log units) above the measured one; low and high end bracket the measured number.
By their numbers in this assay, from the lowest: compounds 3, 2 and 1 (each within the scatter of the next).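

Among these compounds, on the chain of compound 1, 2-phenoxyethyl in place of phenoxy gives a 1.8-fold lower number from compound 1 to compound 3 (0.25 log units; within the scatter) in this assay and is the first step here to bear on the linker. Lengthening the chain this far therefore leaves the number within the usual scatter, as the change of end group did. Nothing measured here offers a reason for this result.

From the compounds shown here alone, whether a shorter chain or a much longer one would also stay within the scatter remains open, as does a chain carrying an amine or a carboxylic acid. The end group of compound 2 on the longer chain of compound 3 is also an open case.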